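A few compounds are considered here, and "the series" means these few. Any claim that something is new, unique, unknown or untested is made for them only; others in the source may bear on it.

Measured in a functional assay on UMUC3 cells (Homo sapiens) for antiproliferative activity, read by MTT assay, with a stated time of 72 h; a higher number here means a weaker inhibitor, a lower number a stronger inhibitor:
- compound 1 `CC(C)CNC(=N)NC(=N)Nc1ccc(F)c(F)c1`: 7100 nM
- compound 2 `CC(C)NC(=N)NC(=N)Nc1ccc(F)c(F)c1`: 25000 nM

Compound 2 has the higher of these two numbers, so it is the weaker inhibitor of the pair. Among the compounds with values here, its nearest neighbour is compound 1, the only other measured compound.

The next compound, compound 3 `CCN(CC)C(=N)NC(=N)Nc1ccc(F)c(F)c1`, has not yet been measured. It keeps the shared core but carries diethylamino in place of isopropylamino on a carbon with a double bond to nitrogen.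

Within the data shown here, only one measured step offers a guide, the exchange of isobutyl for isopropyl on an amine nitrogen, which gave a 3.5-fold higher number from compound 1 to compound 2 (0.55 log units; beyond the scatter). That step is modest and involves a different pair of groups, so it is a rough guide at best. Among the measured compounds shown here, still, the group in compound 1, which has 7100 nM, is larger than the one in compound 2, and diethylamino is likewise larger than isopropylamino. A modest move toward a lower number is therefore expected, estimated as a 2.3-fold lower number from compound 2 to compound 3 (0.36 log units; beyond the scatter) in this assay. For compound 3 the estimated value is 11000 nM, with an expected range of 4000 nM to 30000 nM.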

Compound 3, half-maximal inhibitory concentration: 22100 nM
Beside the measured number, compound 3's estimate is 2.0-fold (0.30 log units) below it; low and high end bracket the measured number.
By their numbers in this assay, from the lowest: compound 1; then compounds 3 and 2 (each within the scatter of the next).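

In this assay, diethylamino in place of isopropylamino on a carbon with a double bond to nitrogen gives a 1.1-fold lower number from compound 2 to compound 3 (0.05 log units; within the scatter), so the larger group here does not bring the lower number that the earlier pair hinted at, even though the count falls from 1 hydrogen-bond donor to 0. Diethylamino in place of isobutylamino at the same place gives a 3.1-fold higher number from compound 1 to compound 3 (0.49 log units; beyond the scatter), which leaves compound 1, at 7100 nM, beyond the scatter of both other compounds and shows that the kind of group matters here, not just its size. Nothing available explains why these groups differ in this way, and no supporting measurement bears on the result.

From the compounds shown here alone, with so few compounds, it remains open whether the lower number of compound 1 belongs to isobutylamino alone or would also appear with a longer chain such as n-butylamino or with a ring such as cyclohexylamino. Ethylamino or dimethylamino at this place would also help separate the effect of chain length from that of having one or two chains on the nitrogen.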